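Methyl to hydrogen on the aromatic core: two matched pairs

The source may report more compounds than this note shows. Statements on the series, on what has been measured and on what is new or still open speak of the compounds shown alone.

Values in a functional assay for inhibition of sodium/hydrogen exchanger (Oryctolagus cuniculus); a lower number here means a stronger inhibitor, a higher number a weaker inhibitor:
compound 1, `Cc1c(C(=O)N=C(N)N)ccc(Cl)c1S(C)(=O)=O`: 1300 nM
compound 2, `CS(=O)(=O)c1cc(C(=O)N=C(N)N)ccc1Cl`: 380 nM
compound 3, `Cc1cc(Oc2cncc(Cl)c2)c(S(C)(=O)=O)cc1C(=O)N=C(N)N`: 14 nM

Compound 2 differs from compound 1 by hydrogen in place of methyl on an aromatic carbon, and this change gave a 3.4-fold lower number from compound 1 to compound 2 (0.53 log units; beyond the scatter). Compound 3 stands lowest of the three in this assay; how its core differs from the core of compound 1 is not broken down here.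

Compound 4, `CS(=O)(=O)c1cc(C(=O)N=C(N)N)ccc1Oc1cncc(Cl)c1`, is not yet measured. It differs from compound 3 by hydrogen in place of methyl on an aromatic carbon, the same kind of change as from compound 1 to compound 2, but around a different place: here para to the methylsulfonyl group and meta to the (5-chloropyridin-3-yl)oxy group, there ortho to the methylsulfonyl group and meta to the chloro group. Among the measured compounds shown here, the only precedent is the step from compound 1 to compound 2, a 3.4-fold lower number from compound 1 to compound 2 (0.53 log units; beyond the scatter), so the expected step is a smaller lowering, a 2.0-fold lower number from compound 3 to compound 4 (0.30 log units; within the scatter), with wide uncertainty. Compound 4 is estimated at 7 nM in this assay, between 2 nM and 30 nM.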

Compound 4, half-maximal inhibitory concentration: 75 nM
Compound 4: the middle estimate sits 11-fold (1.03 log units) below what was measured; measured number outside the range, above it.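

Hydrogen in place of methyl on an aromatic carbon does not carry over from one core to the other in this assay and changes direction: the same change on two cores in this assay, a 3.4-fold lower number (0.53 log units; beyond the scatter) from compound 1 to compound 2 and a 5.4-fold higher number (0.73 log units; beyond the scatter) from compound 3 to compound 4, 18-fold (1.26 log units) apart, beyond the scatter of two such steps

On the core of compound 3, the change gives a 5.4-fold higher number from compound 3 to compound 4 (0.73 log units; beyond the scatter) and so loses part of what the methyl-bearing compound shows, while on the core without methyl, (5-chloropyridin-3-yl)oxy in place of chloro gives a 5.1-fold lower number from compound 2 to compound 4 (0.70 log units; beyond the scatter) as a separate gain. The two methyl groups stand in different places, so these two pairs do not show whether the core or the place decides the direction, and they give no rule for a further core.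

Still open, going by these compounds, is how an ethyl group would compare with methyl at the place on compound 3. Also open, on these data alone, is whether an amine in place of the (5-chloropyridin-3-yl)oxy group would keep the effect of the methyl.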